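This account rests on a few compounds, and the source may have more. Where it says the series, first, only, none or still open, it means among the compounds named here.

Compound 1 `CC(C)(C)OC(=O)NCc1ccccc1NC(=O)c1cccc2ccccc12`: 5 ug/mL
Compound 2 `NC(=O)c1ccc(NC(=O)c2ccc3ccccc3n2)cc1`: 5 ug/mL

In a physicochemical assay for solubility (on this read-out higher numbers stand for higher solubility and lower numbers for lower solubility), compound 1 gives 5 ug/mL, and compound 2 gives 5 ug/mL; the two stand level within the usual scatter, so neither can be called the more soluble one. Compound 3 `NCc1ccccc1NC(=O)c1cccc2ccccc12` has not yet been measured. It differs from compound 1 in one place: hydrogen in place of tert-butoxycarbonyl on an amine nitrogen. Going by the values given here, no measured pair shows this same change, so its size is not known from these data. Compound 3 is nevertheless expected to come out more soluble, with an expected step of a 20-fold higher number from compound 1 to compound 3 (1.30 log units; beyond the scatter). Compound 3 is estimated at 100 ug/mL, in a range from 20 ug/mL to 500 ug/mL.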

Compound 3, solubility: 25 ug/mL
Estimate against measurement, compound 3: 4.0-fold (0.60 log units) above; the range from low to high includes it.
By their numbers in this assay, from the lowest: compounds 1 and 2 (each within the scatter of the next); then compound 3.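

Before this result, the only comparison was between two compounds that stood level and differed in more than one place, so nothing showed how this amine nitrogen behaves. In this assay, hydrogen in place of tert-butoxycarbonyl on an amine nitrogen gives a 5.0-fold higher number from compound 1 to compound 3 (0.70 log units; beyond the scatter) in a modest step, so the read-out does respond to a change at this position. No measurement shown explains this step.

Open, from the compounds shown here alone, is where an acetyl or a methyl group on that nitrogen would fall relative to compound 1 and compound 3. Also open, going by these compounds, is whether the same change on another core gives a step of similar size.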